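The source may report more compounds than this note shows. Statements on the series, on what has been measured and on what is new or still open speak of the compounds shown alone.

Measured compounds in a functional assay on NALM-6 cells (Homo sapiens) for inhibition, read by MTT assay, with a stated time of 48 h; a lower number here means a stronger inhibitor, a higher number a weaker inhibitor:
compound 1 `C=C1C(=O)N(c2ccccc2)N(c2ccccc2)C1c1ccccc1` gives 3820 nM
compound 2 `C=C1CN(C)N(c2ccc(Cl)cc2)C1=O` gives 51900 nM
compound 3 `C=C1C(=O)N(c2ccccc2)N(C)C1c1ccccc1` gives 24400 nM

Compound 2 stands highest of the three numbers, with compound 3 nearest and compound 1 furthest. For the measured compounds named here, the one measured step, a 6.4-fold higher number from compound 1 to compound 3 (0.81 log units; beyond the scatter), concerns a group on a ring nitrogen and does not touch the aromatic substituent.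

Compound 4 `C=C1CN(C)N(c2ccc(C)cc2)C1=O` differs from compound 2 as follows: methyl in place of chloro on an aromatic carbon. Going by the values given here, no measured pair shows a change at this aromatic carbon, so nothing here bears directly on the step, and a step of no more than the scatter is expected in this assay, in either direction.

For compound 4 the estimate is 50000 nM, within 20000 nM to 125000 nM, corresponding to the expected step of a 1.0-fold lower number from compound 2 to compound 4 (0.02 log units; within the scatter).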

Compound 4, half-maximal inhibitory concentration: 90100 nM
Compound 4: middle estimate off by 1.8-fold (0.26 log units), on the low side; low and high end bracket the measured number.
By their numbers in this assay, from the lowest: compound 1; then compound 3; then compounds 2 and 4 (each within the scatter of the next).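

In this assay, for the compounds shown here, methyl in place of chloro on an aromatic carbon gives a 1.7-fold higher number from compound 2 to compound 4 (0.24 log units; within the scatter) and is the first measured change at this position. The two groups are therefore not separated here, unlike the ring nitrogen groups in a 6.4-fold higher number from compound 1 to compound 3 (0.81 log units; beyond the scatter), where the step lies beyond the scatter. No available data give a cause for this result.

Going by these compounds, it remains open whether an amine or a carboxylic acid at this position would give a step beyond the scatter. On these data alone, the same swap on the core of compound 1 also remains open.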